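The source may report more compounds than this note shows. Statements on the series, on what has been measured and on what is new or still open speak of the compounds shown alone.

Compound 1, `[O-][n+]1nc(NCOC2CCCCC2)[n+]([O-])c2ccccc21`, gives 1200 nM in a functional assay on A549 cells (Homo sapiens) for cytotoxicity, read by MTT assay, with a stated time of 72 h; a higher number here means a weaker inhibitor, a lower number a stronger inhibitor.
Compound 2, `COCNc1n[n+]([O-])c2ccccc2[n+]1[O-]`, gives 2770 nM in this assay.
Compound 3, `COc1ccc2c(c1)[n+]([O-])nc(NCOCc1ccccc1)[n+]2[O-]`, gives 4470 nM in this assay.

All three share the same core, an amine bearing a chain that ends in an ether, and differ in what hangs on that ether or on the core. Compound 3 stands at the highest number of the three, but its gap to compound 2 lies within the scatter, so the two cannot be ordered; only its gap to compound 1 is beyond the scatter. Among the compounds with values here, the one step measured within this group, a 2.3-fold higher number from compound 1 to compound 2 (0.36 log units; beyond the scatter), changes the group on the ether oxygen and leaves the core untouched.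

Compound 4, `[O-][n+]1nc(NCOCc2ccccc2)[n+]([O-])c2ccccc21`, is compound 3 with the core stripped of its substituent: hydrogen in place of methoxy on an aromatic carbon. Within the data shown here, no measured step here changes a group on the core, so nothing bears directly on this change. With the ether side unchanged and only a methoxy removed, a step of no more than the scatter is expected in this assay, in either direction. On that basis compound 4 is estimated at 3200 nM, within a range of 1300 nM to 8000 nM, which amounts to an expected 1.4-fold lower number from compound 3 to compound 4 (0.15 log units; within the scatter).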

Compound 4, half-maximal inhibitory concentration: 4140 nM
Estimate against measurement, compound 4: 1.3-fold (0.11 log units) below; the range from low to high includes it.
By their numbers in this assay, from the lowest: compound 1; then compounds 2, 4 and 3 (each within the scatter of the next).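

Taking the methoxy off the shared core, a 1.1-fold lower number from compound 3 to compound 4 (0.03 log units; within the scatter) in this assay and stays within the scatter, so this is the first measured sign that hydrogen and methoxy on this aromatic carbon cannot be told apart here, at least with a benzyl group on the ether. Compound 4 also lets the ether side be read on the unsubstituted core: going a 1.5-fold higher number from compound 2 to compound 4 (0.17 log units; within the scatter) puts phenyl in place of hydrogen on the chain carbon with no readable change, whereas going a 3.5-fold higher number from compound 1 to compound 4 (0.54 log units; beyond the scatter) shows that benzyl in place of cyclohexyl does clear the scatter. Together with the earlier step of a 2.3-fold higher number from compound 1 to compound 2 (0.36 log units; beyond the scatter) this sets compound 1 apart from compound 2 and compound 4, and among the listed steps only those leading away from its cyclohexyl group go beyond the scatter.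

Going by these compounds, whether an amine or a carboxylic acid on this aromatic carbon would shift the number stays open, as does whether the cyclohexyl result would hold on a core that carries methoxy. Nothing measured here explains why the group on the ether oxygen matters while the methoxy does not show.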